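The source may hold more compounds than are shown below. What is called first, only, known or untested is meant among the compounds shown, and "the series" means these compounds.

Working notes on the series. Of the compounds shown here, three have been measured in a functional assay on the whole organism (Tail, strain ICR) with Mus musculus as the target, in the tail flick test, with a stated time of 90 min, at a dose of 25 umol/kg by the oral route; a higher number here means a stronger effect of the compound at the dose given, a lower number a weaker effect. Compound 1 `O=C(CN(c1nc(Cl)nc2[nH]cnc12)C1CC1)N[C@@H](CCC(=O)OCc1ccccc1)C(=O)OCc1ccccc1` gives 50% in this assay. Compound 2 `O=C(CN(c1ncnc2c1ncn2C1CCCCO1)C1CC1)NCC(=O)OCc1ccccc1` gives 25.9% in this assay. Compound 3 `O=C(O)CC[C@H](NC(=O)CN(c1nc(Cl)nc2[nH]cnc12)C1CC1)C(=O)O` gives 44.7% in this assay. On these three numbers compound 3 stands second highest: its number and that of compound 1 lie within the scatter of each other, so no separation between the two can be claimed, whereas the gap to compound 2 lies beyond the scatter.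

Compound 4 `CC[C@H](C)[C@H](NC(=O)CN(c1nc(Cl)nc2[nH]cnc12)C1CC1)C(=O)O` has not yet been measured in this assay. It differs from compound 3 in one place: sec-butyl in place of 2-carboxyethyl on a saturated chain carbon bound to an amide-type nitrogen and a carbonyl carbon. Among the measured compounds shown here, no step between two measured compounds describes this kind of change, so the expectation rests only on the three numbers above. Compound 1 and compound 3, which carry the same side chain skeleton in different forms, give numbers close to one another in this assay, while compound 2, with a shorter chain and another core, gives the lowest number. For compound 4 a step downward from compound 3 of a number 6.7 percentage points lower from compound 3 to compound 4 (within the scatter) is expected, a size that would stay within the scatter. The estimate for compound 4 in this assay is 38%, with a range from 20% to 58%.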

Compound 4, a percentage reported as activity, at one dose (the size of the read-out at that dose, not a potency): 27.4%
For compound 4 the middle estimate is 10.6 percentage points above the measured one, and the stated range covers the measured number.
By their numbers in this assay, from the lowest: compounds 2 and 4 (each within the scatter of the next); then compounds 3 and 1 (each within the scatter of the next).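

In this assay, among the compounds shown here, the change to sec-butyl from 2-carboxyethyl, on a saturated chain carbon bound to an amide-type nitrogen and a carbonyl carbon, gives a number 17.3 percentage points lower from compound 3 to compound 4 (beyond the scatter) and is the only single-place step, showing that the group at this position bears on the read-out. By the counts for the two groups, the change removes a chain with one hydrogen-bond donor and one hydrogen-bond acceptor, takes away one heavy atom and adds a defined stereocentre, so several features alter together and this one step cannot separate them. No accompanying measurement bears on why the number moves.

Still open, going by these compounds, is whether the carboxylic acid at the end of the chain or the shape of the chain matters more: a straight butyl chain would test the branching of sec-butyl, while a primary amide at the end of the 2-carboxyethyl chain would test the acid itself. A longer chain ending in a carboxylic acid, or a chain ending in an amine, would also show how far this position tolerates other groups.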